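Removing the Halogen: From Compound 2 to Compound 3

The source may report more compounds than this note shows. Statements on the series, on what has been measured and on what is new or still open speak of the compounds shown alone.

Of the compounds shown here, two have been measured so far. Compound 1 `CCCCN1CCC(CNC(=O)c2cc(Cl)c(N)c3[nH]cnc23)CC1` gives 22.4 nM in an assay on membranes from striatum with 5-hydroxytryptamine receptor 4 (Rattus norvegicus) as the target (on this read-out lower numbers stand for stronger inhibition and higher numbers for weaker inhibition), and compound 2 `CCCCN1CCC(CNC(=O)c2cc(Br)c(N)c3[nH]cnc23)CC1` gives 27.5 nM. The step of a 1.2-fold higher number from compound 1 to compound 2 (0.09 log units; within the scatter) shows that the two halogens behave alike here. Of the two numbers, that of compound 2 is nominally the larger, but its separation from compound 1 lies within the scatter.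

Compound 3 `CCCCN1CCC(CNC(=O)c2ccc(N)c3[nH]cnc23)CC1` differs from compound 2 by hydrogen in place of bromo on an aromatic carbon; the halogen is removed altogether. Among the compounds with values here, only the step from compound 1 to compound 2 bears on this position, and it was within the scatter, so the data say nothing direct about losing the halogen entirely. Since this change goes beyond a swap of one halogen for another, compound 3 is expected to give a somewhat higher number than compound 2, the expected step being a 2.9-fold higher number from compound 2 to compound 3 (0.46 log units; beyond the scatter). The estimate for compound 3 in this assay is 80 nM, with a range from 25 nM to 300 nM.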

Compound 3, inhibition constant: 115 nM
Compound 3: the middle estimate sits 1.4-fold (0.16 log units) below what was measured; measured number inside the range.
By their numbers in this assay, from the lowest: compounds 1 and 2 (each within the scatter of the next); then compound 3.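

Swapping one halogen for the other on this aromatic carbon, ortho to an amino group, had stayed within the scatter, but removing the halogen altogether does not: hydrogen in place of bromo gives (a 4.2-fold higher number from compound 2 to compound 3 (0.62 log units; beyond the scatter)) and hydrogen in place of chloro gives (a 5.1-fold higher number from compound 1 to compound 3 (0.71 log units; beyond the scatter)). Both steps are modest, yet both lie beyond the scatter. In this assay this position therefore responds to having a halogen at all, while chloro and bromo cannot be told apart.

The compounds shown leave open whether only a halogen serves here, since fluoro, methyl, methoxy and nitrile at this carbon remain outside the set. Nothing available explains why the number rises when the halogen leaves.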